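The source may report more compounds than this note shows. Statements on the series, on what has been measured and on what is new or still open speak of the compounds shown alone.

Measured compounds:
compound 1 `O=C(Nc1ccccc1Cl)c1ccc(/N=N\c2c[nH]c3ccccc23)cc1` — 112000 nM
compound 2 `Cc1ccc(C)c(NC(=O)c2ccc(/N=N\c3c[nH]c4ccccc34)cc2)c1` — 29900 nM
compound 3 `COc1ccccc1NC(=O)c1ccc(/N=N\c2c[nH]c3ccccc23)cc1` — 86500 nM

In a functional assay on MCF7 cells (Homo sapiens) for inhibition, read by MTT assay, with a stated time of 72 h (a lower number here means a stronger inhibitor, a higher number a weaker inhibitor), compound 3 gives 86500 nM, the second highest of the three numbers; its step to compound 1 lies within the scatter, while compound 2 stands apart, with a 2.9-fold higher number from compound 2 to compound 3 (0.46 log units; beyond the scatter). Compound 4 `Cc1cccc(NC(=O)c2ccc(/N=N\c3c[nH]c4ccccc34)cc2)c1` is not yet measured. It differs from compound 3 by 3-methylphenyl in place of 2-methoxyphenyl on an amide-type nitrogen. Within the data shown here, two measured steps bear on this change. The exchange of the methoxy-bearing ring for a methyl-bearing ring has a precedent in the pair of compound 2 and compound 3, where the dimethylated ring carried the lower number, and the step from compound 1 to compound 3 shows that chloro and methoxy on that ring do not separate beyond the scatter. A ring carrying one methyl is therefore expected to sit between the two, so a modest lowering in this assay is expected. Compound 4 is estimated at 50000 nM, within a range of 20000 nM to 120000 nM; this expectation corresponds to a step of a 1.7-fold lower number from compound 3 to compound 4 (0.24 log units; within the scatter).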

Compound 4, half-maximal inhibitory concentration: 73400 nM
For compound 4 the middle estimate is 1.5-fold (0.17 log units) below the measured one; the measured number falls inside the stated range.
By their numbers in this assay, from the lowest: compound 2; then compounds 4, 3 and 1 (each within the scatter of the next).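

In this assay the exchange of 2-methoxyphenyl for 3-methylphenyl on the amide-type nitrogen gives a 1.2-fold lower number from compound 3 to compound 4 (0.07 log units; within the scatter) and the exchange of 2-chlorophenyl for the same group gives a 1.5-fold lower number from compound 1 to compound 4 (0.18 log units; within the scatter) so a ring with one methyl does not separate from the rings with one methoxy or one chloro. The second methyl of compound 2 now stands out as a single change, since hydrogen in place of methyl on an aromatic carbon gives a 2.5-fold higher number from compound 2 to compound 4 (0.39 log units; beyond the scatter) and compound 2 alone lies beyond the scatter of the other three. No measurement shown accounts for this difference.

The compounds shown leave open whether the gap to compound 2 would persist with an ethyl group or a longer chain on the ring. They also leave open how an amine or a carboxylic acid at that place would compare.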